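Swapping the pyridine substituent on a camphor-derived sulfonamide

This account rests on a few compounds, and the source may have more. Where it says the series, first, only, none or still open, it means among the compounds named here.

Compound 1 `CC1(C)[C@@H]2CC[C@@]1(CS(=O)(=O)N1CCN(c3ncccc3C(F)(F)F)CC1)C(=O)C2` was tested in a functional assay on CHO-K1 cells for antagonist activity at C-X-C chemokine receptor type 3 (Homo sapiens), read by FLIPR and calcium flux; a lower number here means a stronger inhibitor, a higher number a weaker inhibitor. Compound 1 reaches only the limit of this assay, > 31600 nM, so no number is known for it; compound 1 therefore stands at the weak end of what is shown, where (the limit of > 31600 nM in this assay, at which 2 of the 3 values shown sit). Compound 3 `CC1(C)[C@@H]2CC[C@@]1(CS(=O)(=O)N1C[C@@H]3C[C@H]1CN3c1ccc(C(F)(F)F)cn1)C(=O)C2` likewise gives only the limit, > 31600 nM. Compound 2 `CC1CN(S(=O)(=O)C[C@]23CC[C@H](CC2=O)C3(C)C)CCN1c1ccc(C(F)(F)F)cn1` gives 316 nM in this assay. Compound 4 `CC(=O)c1ccc(N2CCN(S(=O)(=O)C[C@]34CC[C@H](CC3=O)C4(C)C)CC2)nc1` has not yet been measured; it differs from compound 1 by 5-acetylpyridin-2-yl in place of 3-(trifluoromethyl)pyridin-2-yl on an amine nitrogen in a ring. Within the data shown here, no measured pair traces this step, so the expected step of an at least 21-fold lower number from compound 1 to compound 4 (1.32 log units; beyond the scatter) is uncertain in size. Compound 4 is estimated at 1500 nM, with a likely range from 200 nM to 12000 nM.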

Compound 4, half-maximal inhibitory concentration: > 31600 nM
Compound 4: only a limit was reported (the forecaster's own chance of this, stated with the estimate: 25%); middle value at least 21-fold (1.32 log units) from the limit.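

Among these compounds, compound 1 and compound 4 both reach only a limit, so no step between them can be read: the limit of > 31600 nM in this assay, at which 3 of the 4 values shown sit. The compounds shown leave open whether 5-acetylpyridin-2-yl or 3-(trifluoromethyl)pyridin-2-yl gives the stronger inhibitor on this shared core.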